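Carbamate oxygen substituent and fatty-acid amide hydrolase inhibition

The source may report more compounds than this note shows. Statements on the series, on what has been measured and on what is new or still open speak of the compounds shown alone.

Measured compounds:
compound 1 `CCCCCCCCOc1ccc(NC(=O)Oc2ccccc2F)cc1` gives 19 nM in an assay on H4 cells for inhibition of Fatty-acid amide hydrolase 1 (Homo sapiens); a higher number here means a weaker inhibitor, a lower number a stronger inhibitor
compound 2 `CCCCCCCCOc1ccc(NC(=O)ON=C(C)C)cc1` gives 2.4 nM in this assay
compound 3 `CCCCCCCCOc1ccc(NC(=O)O/N=C/c2cccnc2)cc1` gives 0.8 nM in this assay

Compound 3 gives the lowest number of the three in this assay; both a 3.0-fold lower number from compound 2 to compound 3 (0.48 log units; beyond the scatter) and a 24-fold lower number from compound 1 to compound 3 (1.38 log units; beyond the scatter) are beyond the scatter, so compound 3 is the strongest inhibitor among the measured compounds.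

The next compound, compound 4 `CCCCCCCCOc1ccc(NC(=O)Oc2ccccc2)cc1`, is not yet measured. Relative to compound 3 it carries a group of 6 heavy atoms (6 carbon; one six-membered aromatic ring of carbon only) in place of a group of 8 heavy atoms (6 carbon, 2 nitrogen; one six-membered aromatic ring with 1 hetero atom), on an oxygen next to a carbonyl group. Compound 4 is the plain phenyl carbamate; compound 1 differs from it only by a fluorine on that phenyl. The step bearing most directly on this change is a 24-fold lower number from compound 1 to compound 3 (1.38 log units; beyond the scatter), which runs in the opposite direction and is large; a 7.9-fold lower number from compound 1 to compound 2 (0.90 log units; beyond the scatter) also shows the aryl carbamate of compound 1 as the weaker end of the series. A large rise in this assay is therefore expected on going from compound 3 to compound 4.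

Compound 4 is estimated at 20 nM, with a range of 6 nM to 60 nM. This estimate corresponds to the expected step of a 25-fold higher number from compound 3 to compound 4 (1.40 log units; beyond the scatter).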

Compound 4, half-maximal inhibitory concentration: 5.4 nM
Estimate against measurement, compound 4: 3.7-fold (0.57 log units) above, outside the stated range (below it).
By their numbers in this assay, from the lowest: compound 3; then compound 2; then compound 4; then compound 1.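

Fluoro on the phenyl proves costly in this assay (a 3.5-fold lower number from compound 1 to compound 4 (0.55 log units; beyond the scatter)), so the weak end of the series set by compound 1 belongs partly to that fluoro and not only to the aryl carbamate. The plain phenyl still falls short of both groups that carry a double bond outside aromatic rings (a 2.3-fold higher number from compound 2 to compound 4 (0.35 log units; beyond the scatter); a 6.8-fold higher number from compound 3 to compound 4 (0.83 log units; beyond the scatter)), so the order at this oxygen survives the removal of the fluoro, with a narrower gap. Nothing measured here accounts for these differences.

On these data alone, whether a methoxy or a nitrile on the phenyl would raise the number as fluoro does stays open. Also open, as far as these compounds go, is whether the group of compound 3 needs its ring nitrogen, which a plain phenyl in the same group would test.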